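Methoxyphenyl Position and Growth Inhibition in One Series

The compounds below may be only part of what the source reports. "The series", "measured", "known", "first", "only" and "open" are said of these compounds alone.

Measured compounds in a functional assay on THP-1 cells (Homo sapiens) for inhibition, read by sulforhodamine B assay, with a stated time of 48 h, tested at 50 uM; a lower number here means less inhibition of growth, a higher number more inhibition of growth at the concentration tested:
compound 1 `COc1ccccc1/C=C/C(=O)/C=C/c1ccc(OCc2cn(CCCOc3cc(=O)oc4ccccc34)nn2)c(OC)c1` gives 50%
compound 2 `COc1ccc(/C=C/C(=O)/C=C/c2ccc(OCc3cn(CCCOc4cc(=O)oc5ccccc45)nn3)c(OC)c2)cc1` gives 56%
compound 3 `COc1ccccc1/C=C/C(=O)/C=C/c1ccc(OCc2cn(CCOc3cc(=O)oc4ccccc34)nn2)c(OC)c1` gives 75%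

Compound 1 and compound 2 share a core and differ only by 4-methoxyphenyl in place of 2-methoxyphenyl on a double-bonded chain carbon bound to a double-bonded chain carbon. The measured step is a number 6 percentage points higher from compound 1 to compound 2 (within the scatter), so the two numbers cannot be told apart in this assay.

Compound 3 has a different core; how it differs from the core of compound 1 is not broken down here. Its number in this assay stands beyond the scatter above both compound 1 and compound 2, so among the three measured compounds it shows the most growth inhibition.

Compound 4 `COc1ccc(/C=C/C(=O)/C=C/c2ccc(OCc3cn(CCOc4cc(=O)oc5ccccc45)nn3)c(OC)c2)cc1` differs from compound 3 by 4-methoxyphenyl in place of 2-methoxyphenyl on a double-bonded chain carbon bound to a double-bonded chain carbon. This is the same change, at the same place, as made from compound 1 to compound 2; among the compounds shown it occurs twice in all.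

From compound 3 to compound 4 the step is expected to be a number 3 percentage points higher from compound 3 to compound 4 (within the scatter), small and within the scatter, because the same change earlier gave a number 6 percentage points higher from compound 1 to compound 2 (within the scatter). Compound 4 is therefore estimated at 78% in this assay, expected to lie between 64% and 90%.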

Compound 4, percent growth inhibition at one concentration: 78%
Compound 4: the middle estimate sits on the measured number at the digits printed; the measured number falls inside the stated range.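

On the second core, 4-methoxyphenyl in place of 2-methoxyphenyl on a double-bonded chain carbon bound to a double-bonded chain carbon gives a number 3 percentage points higher from compound 3 to compound 4 (within the scatter) in this assay. Set beside the earlier step, the change shows no detectable difference between the two cores: the same change on two cores in this assay, a number 6 percentage points higher (within the scatter) from compound 1 to compound 2 and a number 3 percentage points higher (within the scatter) from compound 3 to compound 4, 3 percentage points apart, within the scatter of two such steps This shows that, on these two cores, moving from 2-methoxyphenyl to 4-methoxyphenyl leaves the number within the scatter at the one concentration tested; it does not show that the two groups would match at other concentrations, or that the result would carry over to any further core.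

The compounds shown leave open whether a different group in the same place, such as an aminophenyl or a carboxyphenyl, would shift the number beyond the scatter. Also open, going by these compounds, is how the same methoxyphenyl change behaves on a core with a longer chain than that of compound 1.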